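This account rests on a few compounds, and the source may have more. Where it says the series, first, only, none or still open, it means among the compounds named here.

The account follows a single exchange on the sulfonyl sulfur of a shared core, read in a physicochemical assay for solubility, in simulated intestinal fluid, with a stated time of 4 h; on this read-out lower numbers stand for lower solubility and higher numbers for higher solubility. Compound 2 `N#Cc1ccc(O[C@H]2CN(S(=O)(=O)c3ccc(Cl)cn3)C[C@@]2(O)CO)cc1F` is the starting point; in this assay compound 2 gives 26 ug/mL, the higher of the two plain numbers, its nearest neighbour being compound 1 `N#Cc1ccc(O[C@H]2CN(S(=O)(=O)c3ccc(C(F)(F)F)cc3)C[C@@]2(O)CO)cc1F`, which in this assay gives 5 ug/mL. That gap is the step of a 5.2-fold higher number from compound 1 to compound 2 (0.72 log units; beyond the scatter). Compound 3 `N#Cc1ccc(O[C@H]2CN(S(=O)(=O)c3ccc(Cl)cn3)C[C@@]2(O)CN)cc1F` is reported only as a limit of this assay, namely > 1000 ug/mL. The step of an at least 38-fold higher number from compound 2 to compound 3 (1.58 log units; beyond the scatter) runs up to the limit of > 1000 ug/mL in this assay, at which 1 of the 3 values shown sits. Compound 4 `N#Cc1ccc(O[C@H]2CN(S(=O)(=O)c3ccc(Cl)cc3Cl)C[C@@]2(O)CO)cc1F` has not yet been measured; it differs from compound 2 in one place: 2,4-dichlorophenyl in place of 5-chloropyridin-2-yl on a sulfonyl sulfur. The step of a 5.2-fold higher number from compound 1 to compound 2 (0.72 log units; beyond the scatter) is the one that bears on this change, as it too exchanged one aromatic ring for another on the same sulfonyl sulfur, whereas the step toward compound 3 altered a different part of the molecule and offers little guidance here. The exchange from compound 1 to compound 2 moved the read-out by a modest amount, and the change toward compound 4 heads back toward a ring of carbon only, so a modest step down is expected for compound 4 in this assay, a 5.2-fold lower number from compound 2 to compound 4 (0.72 log units; beyond the scatter). Compound 4 is estimated at 5 ug/mL, with a range from 1.5 ug/mL to 15 ug/mL.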

Compound 4, solubility: 19 ug/mL
Estimate against measurement, compound 4: 3.8-fold (0.58 log units) below, and the stated range ends below it.
By their numbers in this assay, from the lowest: compound 1; then compounds 4 and 2 (each within the scatter of the next). At a limit, above all of these: compound 3.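

In this assay, the exchange of 5-chloropyridin-2-yl for 2,4-dichlorophenyl on the sulfonyl sulfur comes to a 1.4-fold lower number from compound 2 to compound 4 (0.14 log units; within the scatter), so at this position a ring of carbon only, without the ring nitrogen and its hydrogen-bond acceptor, does not set itself apart from the ring with the hetero atom. Set against 4-(trifluoromethyl)phenyl, also a ring of carbon only, the same 2,4-dichlorophenyl gives a 3.8-fold higher number from compound 1 to compound 4 (0.58 log units; beyond the scatter), which shows that the gap between these compounds at the sulfonyl sulfur does not follow the ring nitrogen and that rings of carbon only can differ from one another here. What the compounds shown offer gives no measured reason for this difference between the two rings of carbon only.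

As far as these compounds go, it remains open how a ring on this sulfonyl sulfur carrying an amine or a carboxylic acid, rather than chlorine or trifluoromethyl, would read in this assay. From the compounds shown here alone, it is also open whether amino in place of hydroxy on the saturated chain carbon would act on the 2,4-dichlorophenyl compound as it did on the 5-chloropyridin-2-yl compound.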